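Hydroxy to carboxy on the fused core: A-375 growth inhibition

The source may hold more compounds than are shown below. What is called first, only, known or untested is meant among the compounds shown, and "the series" means these compounds.

Measured compounds:
compound 1 `Cc1c(C(=O)Nc2c(F)cc(-c3cccc(F)c3)cc2F)nc2ccc(C(F)(F)F)cc2c1O` — 1.28%
compound 2 `COc1ccc2nc(C(=O)Nc3ccc(-c4ccccc4)cc3)c(C)c(O)c2c1` — 0.56%
compound 3 `Cc1c(C(=O)Nc2c(F)cc(-c3cccc(F)c3)cc2F)nc2ccc(C(F)(F)F)cc2c1C(=O)O` — 0.37%

All three have been run in a functional assay on A-375 cells (Homo sapiens) for antiproliferative activity, read by MTT assay, with a stated time of 24 h, tested at 0.02 ug/mL; a higher number here means a stronger effect of the compound at the concentration tested, a lower number a weaker effect. Compound 1 gives 1.28% and compound 3 gives 0.37%; the two differ only by carboxy in place of hydroxy on an aromatic carbon, and the step is a number 0.9 percentage points lower from compound 1 to compound 3 (within the scatter), so the change leaves the read-out essentially where it was. Compound 2, on a different core, gives 0.56%; its value sits within the scatter of both compound 1 and compound 3, so no order among the three can be stated. How the core of compound 2 differs from the core of compound 1 is not broken down here.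

Compound 4 `COc1ccc2nc(C(=O)Nc3ccc(-c4ccccc4)cc3)c(C)c(C(=O)O)c2c1` has not yet been measured in this assay. For the measured compounds named here, it carries carboxy in place of hydroxy on an aromatic carbon, the same change, at a place described in the same words, as the one made from compound 1 to compound 3. Given that the earlier step was a number 0.9 percentage points lower from compound 1 to compound 3 (within the scatter) and that compound 2 gives 0.56%, the step for compound 4 is expected to be small and of the same kind, estimated at a number 0.3 percentage points lower from compound 2 to compound 4 (within the scatter). Compound 4 is therefore expected to give about 0.3% in this assay, with the range -6% to 6% covering the usual repeat-to-repeat spread at this single concentration.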

Compound 4, a percentage reported as inhibition, at one concentration (the size of the read-out at that concentration, not a potency): 0.68%
Compound 4: middle estimate off by 0.4 percentage points, on the low side; the measured number falls inside the stated range.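

On the core of compound 2, carboxy in place of hydroxy on an aromatic carbon gives a number 0.1 percentage points higher from compound 2 to compound 4 (within the scatter) in this assay, and the step agrees with the earlier one on the core of compound 1: the same change on two cores in this assay, a number 0.9 percentage points lower (within the scatter) from compound 1 to compound 3 and a number 0.1 percentage points higher (within the scatter) from compound 2 to compound 4, 1 percentage points apart, within the scatter of two such steps. Across these two cores, the change therefore leaves the read-out without a shift that can be told from repeat-to-repeat variation at the single concentration tested. This does not show that the change acts alike on the two cores in any wider sense: neither step stands beyond the scatter, so the agreement is between two steps with no discernible size, and it cannot say what the change would do to a compound with a clear effect at this concentration.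

The compounds shown leave open whether another group on this aromatic carbon, such as an amine, a carboxamide or a longer chain, would move the read-out beyond the scatter on either core. Also open, from the compounds shown here alone, is the effect of all four compounds at any other concentration, which a read-out at one concentration does not give.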